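The source may hold more compounds than are shown below. What is called first, only, known or untested is meant among the compounds shown, and "the series" means these compounds.

Measured so far in a functional assay on MCF7 cells (Homo sapiens) for antiproliferative activity; on this read-out higher numbers stand for weaker inhibition and lower numbers for stronger inhibition:
- compound 1 `CC(C)=CCc1cc(C(=O)Nc2cc3ccc(OCCCN(C(C)C)C(C)C)c(C)c3oc2=O)ccc1O`: 1310 nM
- compound 2 `CC(C)=CCc1cc(C(=O)Nc2cc3ccc(OCCCN(C)C(C)(C)C)c(C)c3oc2=O)ccc1O`: 1140 nM

Among the compounds with values here, only these two compounds have numbers so far, and compound 2, at 1140 nM, cannot be told apart from compound 1, since the one step joining them is a 1.1-fold lower number from compound 1 to compound 2 (0.06 log units; within the scatter). The next compound, compound 3 `COC(=O)CNCCCOc1ccc2cc(NC(=O)c3ccc(O)c(CC=C(C)C)c3)c(=O)oc2c1C`, keeps the shared core and changes only the amine end of the chain: ((methoxycarbonyl)methyl)amino in place of methyl(tert-butyl)amino on a saturated chain carbon, three bonds along the chain from an oxygen on an aromatic ring. The new group, ((methoxycarbonyl)methyl)amino, sits on a saturated chain carbon, three bonds along the chain from an oxygen on an aromatic ring.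

Within the data shown here, the single measured step bears on this only loosely. It exchanges diisopropylamino for methyl(tert-butyl)amino, and neither group contains a methoxycarbonyl unit, so the data do not reach this change directly. The flat result in this assay offers no sign of a large shift, but it cannot rule one out. A modest move towards a higher number is expected, with wide uncertainty in either direction. The expected change is a 1.8-fold higher number from compound 2 to compound 3 (0.24 log units; within the scatter). Compound 3 is estimated at 2000 nM, with an expected range from 600 nM to 7000 nM.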

Compound 3, half-maximal inhibitory concentration: 2820 nM
Estimate against measurement, compound 3: 1.4-fold (0.15 log units) below, and the stated range covers the measured number.
By their numbers in this assay, from the lowest: compounds 2 and 1 (each within the scatter of the next); then compound 3.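

In this assay the amine end of the chain now gives steps that stand clear of the scatter, which the exchange of diisopropylamino for methyl(tert-butyl)amino had not done: ((methoxycarbonyl)methyl)amino in place of methyl(tert-butyl)amino gives a rise (a 2.5-fold higher number from compound 2 to compound 3 (0.39 log units; beyond the scatter)), and in place of diisopropylamino it gives a rise of similar size (a 2.2-fold higher number from compound 1 to compound 3 (0.33 log units; beyond the scatter)). Both steps are modest, but they show that the group on a saturated chain carbon, three bonds along the chain from an oxygen on an aromatic ring, can move this read-out even when the entering and leaving groups have the same number of heavy atoms. Nothing measured here explains the rise.

Compound 3 differs from the other two in several ways at once, since its group brings in an ester and a hydrogen on the amine nitrogen, so the three compounds cannot show which of these features goes with the higher number. On these data alone, it remains open how a carboxylic acid in place of the methyl ester, a tert-butylamino group without the methyl, or a longer chain between the oxygen and the amine would read in this assay.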